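A ring of carbon only on the carbonyl carbon

The source may report more compounds than this note shows. Statements on the series, on what has been measured and on what is new or still open speak of the compounds shown alone.

Within the data shown here, in a physicochemical assay for lipophilicity, using the shake flask method, in phosphate buffer, measured as octanol-water partition, at pH 7.4 (on this read-out lower numbers stand for lower lipophilicity and higher numbers for higher lipophilicity), compound 1 (`CCN(Cc1ccncc1)C(=O)Cn1c(=O)n(C)c2cnc(-c3ccccc3)nc21`) gives 2.03 and compound 2 (`CN(Cc1cccnc1)C(=O)Cn1c(=O)n(C)c2cnc(-c3ccccc3)nc21`) gives 1.81, so compound 2 stands within the scatter of its only measured neighbour. Compound 3 (`CCN(Cc1ccccc1)C(=O)Cn1c(=O)n(C)c2cnc(-c3ccccc3)nc21`) carries benzyl(ethyl)amino in place of methyl((pyridin-3-yl)methyl)amino on a carbonyl carbon. Among the measured compounds shown here, the one measured step, a number 0.22 log units lower from compound 1 to compound 2 (within the scatter), keeps a ring with a hetero atom on both sides, so it gives no direct size for this change. With a ring of carbon only entering, a clear rise in this assay is nevertheless expected, the estimated step being a number 1.29 log units higher from compound 2 to compound 3 (beyond the scatter). For compound 3 the estimate is 3.1, with an expected range of 2.6 to 3.6.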

Compound 3, distribution coefficient: 3.48
For compound 3 the middle estimate is 0.38 log units below the measured one; low and high end bracket the measured number.
By their numbers in this assay, from the lowest: compounds 2 and 1 (each within the scatter of the next); then compound 3.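

In this assay the ring of carbon only on the carbonyl carbon sets compound 3 clearly apart from both compounds whose ring has a hetero atom. Among these compounds, the step is a number 1.67 log units higher from compound 2 to compound 3 (beyond the scatter) and, where phenyl in place of pyridin-4-yl is the only change, a number 1.45 log units higher from compound 1 to compound 3 (beyond the scatter). Nothing measured here gives a reason for the size of these steps. Open, going by these compounds, is where an amine or a carboxylic acid on the phenyl ring would fall in this assay, and what a longer chain in place of ethyl would do.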